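The source may hold more compounds than are shown below. What is called first, only, known or untested is meant among the compounds shown, and "the series" means these compounds.

Measured so far in an ADME assay on MDBK cells (Bos taurus) for cytotoxicity, read by MTT assay, with a stated time of 96 h; a higher number here means that more compound is tolerated, a lower number that less compound is tolerated:
- Compound 1 `CC(=O)c1ccc2[nH]c(-c3ccccc3)nc2c1`: > 100000 nM
- Compound 2 `C/C(=N\NC(N)=O)c1ccc2[nH]c(-c3ccc(C(F)(F)F)cc3)nc2c1`: > 100000 nM
- Compound 3 `CC(=O)c1ccc2c(c1)nc(-c1ccccc1)n2C1CCCCC1`: > 100000 nM

Each of these entries is a limit of the assay and not a number. Compound 3 therefore has no exact figure and stands with the other two at the limit of > 100000 nM in this assay, at which 3 of the 3 values shown sit.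

Compound 4 `COc1ccc(-c2nc3cc(C(C)=O)ccc3n2C2CCCCC2)cc1` keeps compound 3 intact apart from one change: methoxy in place of hydrogen on an aromatic carbon. In words, this is methoxy in place of hydrogen on an aromatic carbon, which turns phenyl to 4-methoxyphenyl.

Among the measured compounds shown here, only one measured step is available, a step that the two limits leave unreadable from compound 1 to compound 3. It concerns an aromatic nitrogen rather than an aromatic carbon, and it gives no size to carry over.

The expectation rests mainly on compound 3, which gives > 100000 nM, a limit. Another limit is the most likely report in this assay. The estimated change, a number no higher from compound 3 to compound 4 (the limit leaves the size open), is expected to stay within the usual scatter, with no clear direction. For compound 4 the estimate is 100000 nM, with an expected range from 40000 nM to 150000 nM.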

Compound 4, half-maximal cytotoxic concentration: > 100000 nM
Compound 4 was reported as a limit (the forecaster's own chance of this, stated with the estimate: 70%); the middle value lies on the limit itself.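

Compound 3 and compound 4 are both reported as limits and not as numbers, so the step between them has no readable size: the limit of > 100000 nM in this assay, at which 4 of the 4 values shown sit.

In this assay the compounds shown leave open at what concentration any of them harms the cells, and whether adding methoxy or cyclohexyl shifts that concentration.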